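This account rests on a few compounds, and the source may have more. Where it says the series, first, only, none or still open, it means among the compounds named here.

Of the compounds shown here, three have been tested in a functional assay on SK-BR-3 cells (Homo sapiens) for antiproliferative activity, read by MTT assay, with a stated time of 72 h; a lower number here means a stronger inhibitor, a higher number a weaker inhibitor: compound 1 `C#CCOC(=O)C[C@@H]1C(C(=O)OC)=CO[C@@H](O[C@@H]2O[C@H](COC(C)=O)[C@@H](OC(C)=O)[C@H](OC(C)=O)[C@H]2OC(C)=O)/C1=C/C`, compound 2 `C/C=C1/[C@H](O[C@@H]2O[C@H](COC(C)=O)[C@@H](OC(C)=O)[C@H](OC(C)=O)[C@H]2OC(C)=O)OC=C(C(=O)OC)[C@H]1CC(=O)OCCC(C)C` and compound 3 `C/C=C1/[C@H](O[C@@H]2O[C@H](CO)[C@@H](O)[C@H](O)[C@H]2O)OC=C(C(=O)OC)[C@H]1CC(=O)OCCC(C)C`. Compound 2 gives > 15000 nM, which is a limit of the assay and not a number. Compound 1 gives > 15000 nM, which is also a limit. Together they make up (the limit of > 15000 nM in this assay, at which 2 of the 3 values shown sit), so compound 2 has no exact place on the scale. Compound 3 is the only one of the three with a measured number, 9020 nM.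

The next compound is compound 4 `C/C=C1/[C@H](O[C@@H]2O[C@H](COC(C)=O)[C@@H](OC(C)=O)[C@H](OC(C)=O)[C@H]2OC(C)=O)OC=C(C(=O)OC)[C@H]1CC(=O)OCCCC`. It differs from compound 2 in one place: hydrogen in place of methyl on a saturated chain carbon bound to two saturated chain carbons. This is hydrogen in place of methyl on a saturated chain carbon bound to two saturated chain carbons, a change that can also be read as isopentyl to butyl.

For the measured compounds named here, only one measured step bears on this change, a step that the two limits leave unreadable from compound 1 to compound 2, and it has no readable size to carry over. No change in either direction beyond the scatter is therefore expected in this assay, and another limit is the likeliest report. The expected step, a step that the limit leaves unreadable from compound 2 to compound 4, is only an estimate. Compound 4 is estimated at 18000 nM, with an expected range from 9000 nM to 36000 nM.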

Compound 4, half-maximal inhibitory concentration: > 15000 nM
Compound 4: only a limit was reported (the forecaster's own chance of this, stated with the estimate: 75%); the middle value does not contradict the limit.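

In this assay compound 4 gives > 15000 nM, which is a limit and not a number. No step from compound 1 or compound 2 to compound 4 can be read, and all three stand at the same limit: the limit of > 15000 nM in this assay, at which 3 of the 4 values shown sit.

The compounds shown leave open whether isopentyl and butyl differ at all in this assay.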